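Swapping the aryl on a triazole for a benzothiazole

A few compounds are considered here, and "the series" means these few. Any claim that something is new, unique, unknown or untested is made for them only; others in the source may bear on it.

Measured compounds:
Compound 1 `CC(C)(C)OC(=O)N1CCN(C(=O)c2cn(-c3ccc(C(F)(F)F)cc3)nn2)CC1` gives 13.6 nM in an assay on HEK293 cells for agonist activity at Glucose-dependent insulinotropic receptor (Homo sapiens), read by a luciferase reporter, with a stated time of 24 h; on this read-out lower numbers stand for an effect already at smaller amounts and higher numbers for an effect only at larger amounts of compound.
Compound 2 `CC(C)(C)OC(=O)N1CCN(C(=O)c2cn(-c3ccc(C(F)(F)F)cc3Cl)nn2)CC1` gives 8.78 nM in this assay.

For the measured compounds named here, compound 1 stands within the usual scatter of compound 2, the only other measured compound, and the step of a 1.5-fold lower number from compound 1 to compound 2 (0.19 log units; within the scatter) is the sole measured step. Compound 3 `CC(C)(C)OC(=O)N1CCN(C(=O)c2cn(-c3nc4ccccc4s3)nn2)CC1` differs from compound 1 by 1,3-benzothiazol-2-yl in place of 4-(trifluoromethyl)phenyl on an aromatic nitrogen. Going by the values given here, that one measured step concerns a chloro added to the aromatic ring, not the exchange of the whole aromatic group, so no measured step bears on this change and the expectation must be wide. For compound 3 in this assay the expected step is a 1.8-fold higher number from compound 1 to compound 3 (0.26 log units; within the scatter), giving an estimate of 25 nM with a range from 6 nM to 100 nM.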

Compound 3, half-maximal effective concentration: 7.12 nM
Compound 3: the middle estimate sits 3.5-fold (0.55 log units) above what was measured; the measured number falls inside the stated range.
By their numbers in this assay, from the lowest: compounds 3, 2 and 1 (each within the scatter of the next).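

In this assay, 1,3-benzothiazol-2-yl in place of 4-(trifluoromethyl)phenyl gives a 1.9-fold lower number from compound 1 to compound 3 (0.28 log units; within the scatter). Where the earlier step covered only a chloro added to the aromatic ring, this one shows that the whole aromatic group on this nitrogen can be exchanged, for one with sulfur and a ring nitrogen and without fluorine, while the number stays within the scatter. Nothing shown here gives a reason for this result. Still open, going by these compounds, is whether an amine or a carboxylic acid on the 1,3-benzothiazol-2-yl group, or a simple alkyl chain in its place, would keep the number in this range.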